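The compounds below may be only part of what the source reports. "The series", "measured", "known", "first", "only" and "open" are said of these compounds alone.

In a functional assay on SiHa cells (Homo sapiens) for inhibition, read by CCK-8 assay, with a stated time of 72 h, tested at 10 uM (on this read-out higher numbers stand for more inhibition of growth at the one concentration tested and lower numbers for less inhibition of growth), compound 1 `CN(C)C(=O)c1cc2cnc(Nc3ccc(NC(=O)C4(C(=O)Nc5ccccc5F)CC4)cc3)nc2n1C1CCCC1` gives 103% and compound 2 `CN(C)C(=O)c1cc2cnc(Nc3ccc(NC(=O)C4(C(=O)Nc5ccc(Br)cc5)CC4)cc3)nc2n1C1CCCC1` gives 98.8%, two values within the scatter of each other. Compound 3 `CN(C)C(=O)c1cc2cnc(Nc3ccc(NC(=O)C4(C(=O)Nc5ccc(F)cc5)CC4)cc3F)nc2n1C1CCCC1` gives 44.4%, which lies well beyond the scatter under compound 2, so compound 2 belongs to the upper pair of these three numbers.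

Compound 4 `CN(C)C(=O)c1cc2cnc(Nc3ccc(NC(=O)C4(C(=O)Nc5ccc(O)cc5)CC4)cc3)nc2n1C1CCCC1` differs from compound 2 in one group only: hydroxy in place of bromo on an aromatic carbon. In words, hydroxy stands in place of bromo on an aromatic carbon.

Among the compounds with values here, the one measured step on this same phenyl group is a number 4.2 percentage points lower from compound 1 to compound 2 (within the scatter), with 4-bromophenyl in place of 2-fluorophenyl. Within the data shown here, that step exchanges one halogen-bearing group for another, and no measured compound carries a hydroxy, so it is only a weak guide. Compound 3 differs from compound 2 in more than one place and cannot isolate this change.

The likeliest outcome is therefore no step beyond the scatter, with more room downward than upward. The expected step is a number 8.8 percentage points lower from compound 2 to compound 4 (within the scatter) in this assay for now. Compound 4 is expected at 90%, with an estimated range from 60% to 104%.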

Compound 4, percent growth inhibition at one concentration: 94.3%
Compound 4: the middle estimate sits 4.3 percentage points below what was measured, within the range that was stated.
By their numbers in this assay, from the lowest: compound 3; then compounds 4, 2 and 1 (each within the scatter of the next).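

In this assay, within the data shown here, the phenyl group had so far carried only halogens, and a hydroxy group, which counts one hydrogen-bond donor and one acceptor where bromo counts none, gives no step beyond the scatter: a number 4.5 percentage points lower from compound 2 to compound 4 (within the scatter). The comparison with the 2-fluorophenyl group also stays within the scatter, at a number 8.7 percentage points lower from compound 1 to compound 4 (within the scatter), so compound 1, compound 2 and compound 4 cannot be told apart in this read-out, even though the substituent on the phenyl group differs among them. Nothing shown here gives a reason for this result.

All three values lie close to full inhibition at a single concentration, so any real differences in strength among these compounds could stay hidden. As far as these compounds go, whether the 4-position would accept an amine, a carboxylic acid or a longer chain remains open.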